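This account rests on a few compounds, and the source may have more. Where it says the series, first, only, none or still open, it means among the compounds named here.

Compound 3 `CN1CC2C=C(c3cncc(Cl)c3)CC(C2)C1` is the chloro member of a small set of three related compounds tested in an in vitro assay on SH-SY5Y cells for displacement of a labelled ligand from Neuronal acetylcholine receptor; alpha3/beta4 (Homo sapiens); on this read-out lower numbers stand for stronger inhibition and higher numbers for weaker inhibition. There compound 3 gives 1830 nM. Compound 1 `COc1cncc(C2=CC3CC(C2)CN(C)C3)c1`, the methoxy member, gives 596 nM, and compound 2 `CN1CC2C=C(c3cncc(C#N)c3)CC(C2)C1`, the cyano member, gives 4500 nM. Compound 3 therefore stands second highest of the three: a 3.1-fold higher number from compound 1 to compound 3 (0.49 log units; beyond the scatter) and a 2.5-fold lower number from compound 2 to compound 3 (0.39 log units; beyond the scatter). Compound 4 `Clc1cncc(C2=CC3CNCC(C2)C3)c1` is not yet measured. It differs from compound 3 by hydrogen in place of methyl on an amine nitrogen in a ring. All three measured steps, including a 7.6-fold higher number from compound 1 to compound 2 (0.88 log units; beyond the scatter), change only the aromatic substituent, so none bears directly on this change at the ring nitrogen. With no guide to size or direction, a change within the scatter is the most defensible expectation, and compound 4 is estimated at 1500 nM with a range from 400 nM to 6000 nM, a step of a 1.2-fold lower number from compound 3 to compound 4 (0.09 log units; within the scatter).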

Compound 4, inhibition constant: 40 nM
The estimate for compound 4 lay 38-fold (1.57 log units) above the measured number, outside the stated range (below it).
By their numbers in this assay, from the lowest: compound 4; then compound 1; then compound 3; then compound 2.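

Replacing the methyl on the amine nitrogen in a ring with hydrogen gives a 46-fold lower number from compound 3 to compound 4 (1.66 log units; beyond the scatter) and is a larger step than any of the changes to the aromatic substituent. The earlier compounds shown here all keep this methyl, so they could not show that this nitrogen, in this one pair, has so strong an effect on the number. Nothing measured here explains the size of this step.

From the compounds shown here alone, it remains open how a larger group on this nitrogen, such as ethyl or benzyl, would compare. Going by these compounds, it also remains open whether the same change would give a step of similar size with methoxy or cyano on the aromatic ring.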